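Ethenyl insertion into the anilide arm of compound 3

The source may hold more compounds than are shown below. What is called first, only, known or untested is meant among the compounds shown, and "the series" means these compounds.

Compound 3 `Nc1ccccc1NC(=O)c1ccc(Cn2cnc3c(NCc4ccccc4)nc(Cl)nc32)cc1` stands highest of the three measured compounds: in a functional assay on HCT-116 cells (Homo sapiens) for antiproliferative activity, read by CCK-8 assay, with a stated time of 72 h, tested at 8 uM (a lower number here means a weaker effect, a higher number a stronger effect of the compound at the concentration tested), compound 3 gives 78.4%, whereas compound 1 `CC1CCN(c2nc(Cl)nc3c2ncn3Cc2ccc(/C=C/C(=O)Nc3ccccc3N)cc2)CC1` gives 26.9% and compound 2 `Cc1ccc(Nc2nc(Cl)nc3c2ncn3Cc2ccc(/C=C/C(=O)Nc3ccccc3N)cc2)cc1` gives 15%. Compound 4 `Nc1ccccc1NC(=O)/C=C/c1ccc(Cn2cnc3c(NCc4ccccc4)nc(Cl)nc32)cc1` differs from compound 3 in one place: 2-((2-aminophenyl)carbamoyl)ethenyl in place of (2-aminophenyl)carbamoyl on an aromatic carbon. For the measured compounds named here, no measured step changes this arm; the only measured step, a number 11.9 percentage points lower from compound 1 to compound 2 (beyond the scatter), concerns the other end of the shared core. Compounds 1 and 2 both carry the 2-((2-aminophenyl)carbamoyl)ethenyl group and give low numbers, yet they also differ from compound 3 at a second site, so the guidance is weak. A drop beyond the scatter is therefore expected, with wide uncertainty, the expected step being a number 23.4 percentage points lower from compound 3 to compound 4 (beyond the scatter). Compound 4 is expected to give 55% (range 25% to 85%).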

Compound 4, a percentage reported as inhibition, at one concentration (the size of the read-out at that concentration, not a potency): 17.4%
Compound 4: the middle estimate sits 37.6 percentage points above what was measured, outside the stated range (below it).
By their numbers in this assay, from the lowest: compounds 2, 4 and 1 (each within the scatter of the next, the first and the last beyond it); then compound 3.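

In this assay, the 2-((2-aminophenyl)carbamoyl)ethenyl arm alone, with benzylamino held constant, gives a number 61 percentage points lower from compound 3 to compound 4 (beyond the scatter), a large loss that compounds 1 and 2, differing from compound 3 at a second site, could not isolate. With this arm in place, the other end of the shared core does not separate the compounds: benzyl in place of 4-methylphenyl gives a number 2.4 percentage points higher from compound 2 to compound 4 (within the scatter), and benzylamino in place of 4-methylpiperidin-1-yl gives a number 9.5 percentage points lower from compound 1 to compound 4 (within the scatter). Nothing available gives a cause for the loss.

As far as these compounds go, whether a saturated ethylene chain in place of the ethenyl group would retain the read-out of compound 3 stays open. So does the effect of a hydroxamic acid in place of the 2-aminophenyl amide.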